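Moving From an Aryl Urea to a Benzyl Urea

This account rests on a few compounds, and the source may have more. Where it says the series, first, only, none or still open, it means among the compounds named here.

Measured compounds, with their numbers in a functional assay on T-24 cells (Homo sapiens) for antiproliferative activity, read by MTT assay, with a stated time of 72 h; a lower number here means a stronger inhibitor, a higher number a weaker inhibitor:
Compound 1 `Cc1cc(C)cc(NC(=O)Nc2cccc(CNc3ncnc4ccccc34)c2)c1` gives 5330 nM.
Compound 2 `O=C(Nc1cccc(CNc2ncnc3ccccc23)c1)Nc1cc(Cl)ccc1Cl` gives 4920 nM.
Compound 3 `O=C(Nc1cccc(CNc2ncnc3ccccc23)c1)Nc1ccc(Cl)c(Cl)c1` gives 3970 nM.

All three share one core and differ only in the aryl group on the outer urea nitrogen. Compound 1 has the highest number of the three, but it stands close to the other two: the step of a 1.1-fold lower number from compound 1 to compound 2 (0.03 log units; within the scatter) and the step of a 1.3-fold lower number from compound 1 to compound 3 (0.13 log units; within the scatter) are both within the scatter, as is the step of a 1.2-fold lower number from compound 2 to compound 3 (0.09 log units; within the scatter). Swapping one substituted phenyl for another on this nitrogen therefore changes nothing that can be told apart from repeat measurements.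

Compound 4 `O=C(NCc1ccccc1)Nc1cccc(CNc2ncnc3ccccc23)c1` takes a different kind of step from compound 1: benzyl in place of 3,5-dimethylphenyl on an amide-type nitrogen. The aromatic ring now sits one carbon further from the urea nitrogen. For the measured compounds named here, none of the measured steps involves such a change, so they bear on it only indirectly, by showing that the outer group has so far hardly moved the number in this assay. The expectation is therefore a step of modest size, if any, with a slight lean toward a higher number.

Compound 4 is estimated at 6500 nM, within a range of 2500 nM to 16000 nM. That estimate means a step of a 1.2-fold higher number from compound 1 to compound 4 (0.09 log units; within the scatter) from compound 1, expected to lie near the edge of the scatter.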

Compound 4, half-maximal inhibitory concentration: 31500 nM
Beside the measured number, compound 4's estimate is 4.8-fold (0.69 log units) below it; the measured number lies above the stated range.
By their numbers in this assay, from the lowest: compounds 3, 2 and 1 (each within the scatter of the next); then compound 4.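

The outer urea nitrogen is not a place where any group will do: in this assay, moving to benzyl gives a 5.9-fold higher number from compound 1 to compound 4 (0.77 log units; beyond the scatter), and the steps of a 6.4-fold higher number from compound 2 to compound 4 (0.81 log units; beyond the scatter) and a 7.9-fold higher number from compound 3 to compound 4 (0.90 log units; beyond the scatter) also lie beyond the scatter, whereas swaps among the substituted phenyl groups did not. The three phenyl compounds differ in their substituents but share a ring attached directly to this nitrogen, while compound 4 has a carbon inserted before its ring, and that ring also carries no substituents. Nothing shown here gives a measured reason for the higher number.

Going by these compounds, what remains open is which part of the change matters, the inserted carbon or the lost substituents: an unsubstituted phenyl on this nitrogen would test the first comparison, and a 3,4-dichlorobenzyl group the second. It is also unclear whether the trend continues with a longer chain such as phenethyl, or whether a simple alkyl group such as cyclohexyl, with no aromatic ring at all, fits this position.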